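Sulfamoyl variation on a triazine aniline acyl sulfonamide

The source may report more compounds than this note shows. Statements on the series, on what has been measured and on what is new or still open speak of the compounds shown alone.

Measured compounds: compound 1 `CC(C)C(=O)NCCS(=O)(=O)NC(=O)c1ccc(Nc2nc(NC3(c4ccc(Cl)cc4)CC3)nc(OCC(F)(F)F)n2)cc1`, 84%; compound 2 `O=C(NS(=O)(=O)CCNC(=O)C1CC1)c1ccc(Nc2nc(NC3(c4ccc(Cl)cc4)CC3)nc(OCC(F)(F)F)n2)cc1`, "not active" (no number reported).

In an ADME assay on microsomes from liver (Rattus norvegicus) for metabolic stability, with a stated time of 10 min (on this read-out higher numbers stand for a more stable compound and lower numbers for a less stable compound), compound 1 gives 84%, the only number among the compounds shown; compound 2 is reported in this assay only as "not active" (no number reported), without a number. The unmeasured compound 3 `CN(C)S(=O)(=O)NC(=O)c1ccc(Nc2nc(NC3(c4ccc(Cl)cc4)CC3)nc(OCC(F)(F)F)n2)cc1` differs from compound 1 in one place: dimethylamino in place of 2-((isopropylcarbonyl)amino)ethyl on a sulfonyl sulfur. Among the measured compounds shown here, with no measured pair bracketing this change, the step in this assay from compound 1 to compound 3 is expected to stay within the scatter, a number 1 percentage points higher from compound 1 to compound 3 (within the scatter). Compound 3 is therefore estimated at 85%, with a range from 65% to 98%.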

Compound 3, percent of the compound remaining: 76%
Beside the measured number, compound 3's estimate is 9 percentage points above it; measured number inside the range.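

Under this assay, replacing 2-((isopropylcarbonyl)amino)ethyl with dimethylamino on the sulfonyl sulfur gives a number 8 percentage points lower from compound 1 to compound 3 (within the scatter), so this position now has two numbers that lie within the scatter of each other. The read-out thus holds across this exchange, although dimethylamino has fewer heavy atoms and no hydrogen-bond donor. Nothing available here explains this result. Still open, as far as these compounds go, is how a primary amine, a carboxylic acid or a longer alkyl chain on the sulfonyl sulfur would read in this assay.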